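The source may report more compounds than this note shows. Statements on the series, on what has been measured and on what is new or still open speak of the compounds shown alone.

Measured so far, in an ADME assay on Vero cells (Chlorocebus sabaeus) for cytotoxicity, read by MTT assay, with a stated time of 72 h; a lower number here means that less compound is tolerated, a higher number that more compound is tolerated:

compound 1 `Cc1ccc(SCC(=O)c2c(C)[n+]([O-])c3ccccc3[n+]2[O-])cc1` — compound 1 gives 50 ug/mL in this assay.
compound 2 `Cc1c(C(=O)CSCCNC(=O)c2ccccc2)[n+]([O-])c2ccccc2[n+]1[O-]` — compound 2 gives only > 100 ug/mL in this assay, which is a limit of the assay and not a number.

Compound 2 thus stands at the limit, as noted in the limit of > 100 ug/mL in this assay, at which 1 of the 2 values shown sits, while compound 1 gives a number within the range. Among the measured compounds shown here, no step between two measured compounds is known here, so the size of a change in this assay has not been measured anywhere.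

The unmeasured compound 3 `Cc1c(C(=O)CSCCNC(=O)c2ccncc2)[n+]([O-])c2ccccc2[n+]1[O-]` differs from compound 2 by pyridin-4-yl in place of phenyl on a carbonyl carbon, the rest of the molecule staying as it is. For the measured compounds named here, no measured step on this kind of change exists in the set. The step that the limit leaves unreadable from compound 2 to compound 3 is expected to be none beyond the scatter. Compound 3 is therefore estimated at 120 ug/mL, with a range from 60 ug/mL to 250 ug/mL, and the assay is expected most likely to report only a limit again.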

Compound 3, half-maximal cytotoxic concentration: 50 ug/mL
Beside the measured number, compound 3's estimate is 2.4-fold (0.38 log units) above it; measured number below the stated range.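

In this assay, among the compounds shown here, pyridin-4-yl in place of phenyl on a carbonyl carbon gives the first step: an at least 2.0-fold lower number from compound 2 to compound 3 (0.30 log units; that floor lies within the scatter). This change at this place moves the series off the limit, since compound 3 reads as a number within the range of this assay. Only a floor can be read for the step, and its full size stays unknown, because compound 2 stands at a limit of the assay and not at a number: the limit of > 100 ug/mL in this assay, at which 1 of the 3 values shown sits.

Open, going by these compounds, is how a carboxylic acid or an amine would read in place of phenyl on a carbonyl carbon. Also open, on these data alone, is whether the same change from phenyl to pyridin-4-yl gives a similar step on a longer chain.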